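Taking One Chloro Group Off Compound 1

This account rests on a few compounds, and the source may have more. Where it says the series, first, only, none or still open, it means among the compounds named here.

Compound 1 `COc1cc(CCc2ccc(Cl)c(Cl)c2)cc(OC)c1O`: 2520 nM
Compound 2 `COc1ccc(CCc2ccc([N+](=O)[O-])cc2)cc1OC`: > 25000 nM (a limit)

Among the compounds with values here, in a functional assay on MDA-MB-231 cells (Homo sapiens) for antiproliferative activity, read by MTT assay, with a stated time of 72 h (a higher number here means a weaker inhibitor, a lower number a stronger inhibitor), compound 1 gives 2520 nM, the only actual number among the compounds measured so far. Compound 2 is reported at > 25000 nM, which is a limit of the assay and not a number.

Compound 3 `COc1cc(CCc2ccc(Cl)cc2)cc(OC)c1O` keeps the core of compound 1 and differs in one place: hydrogen in place of chloro on an aromatic carbon, ortho to a chloro group. Within the data shown here, no measured step between close relatives shows what such a change does in this assay, so the expectation rests on the structural change alone: a modest weakening, perhaps only just beyond the scatter. The expected size is a 2.0-fold higher number from compound 1 to compound 3 (0.30 log units; within the scatter). For compound 3 the estimated value is 5000 nM, with an expected range from 2000 nM to 14000 nM.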

Compound 3, half-maximal inhibitory concentration: > 25000 nM
Compound 3 ended at the assay's limit (the forecaster's own chance of this, stated with the estimate: 8%); middle value at least 5.0-fold (0.69 log units) away from the limit.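

The second chloro group of compound 1 turns out to matter far more than a small adjustment would: in this assay, putting hydrogen on this aromatic carbon, ortho to a chloro group and meta to a large group, gives an at least 9.9-fold higher number from compound 1 to compound 3 (0.99 log units; beyond the scatter). Within the data shown here, this is the first step that can be read, and it shows that the single remaining chloro group does not hold a measurable value in this assay. Compound 3 sits at a limit of the assay, not at a number, so the step has a lower bound only and its full size is unknown: the limit of > 25000 nM in this assay, at which 2 of the 3 values shown sit.

Going by these compounds, what stays open is whether a bromo or trifluoromethyl group on this same carbon would bring back a measurable value. The compounds shown also leave unknown what the other chloro group contributes on its own.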